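The source may report more compounds than this note shows. Statements on the series, on what has been measured and on what is new or still open speak of the compounds shown alone.

Compound 3 `CC[C@@H](C)[C@H](NC(=O)c1ccc(C(CC)(CC)c2ccc(OCC(O)C(C)(C)C)c(C)c2)n1CC)C(=O)OC` gives 26 nM in an assay on HL-60 cells for agonist activity at vitamin D3 receptor (Homo sapiens), read by microscopy, with a stated time of 96 h (on this read-out lower numbers stand for an effect already at smaller amounts and higher numbers for an effect only at larger amounts of compound), the lowest number of the three measured, with compound 1 `CC[C@@H](C)[C@H](NC(=O)c1ccc(C(CC)(CC)c2ccc(OCC(=O)C(C)(C)C)c(C)c2)n1CC)C(=O)OC` at 590 nM and compound 2 `CCn1c(C(=O)N(C)c2ccccc2)ccc1C(CC)(CC)c1ccc(OCC(=O)C(C)(C)C)c(C)c1` at 18500 nM. The steps already seen are a 23-fold lower number from compound 1 to compound 3 (1.36 log units; beyond the scatter), which installs the 1-hydroxy-2,2-dimethylpropyl group that compound 3 and compound 4 share, and a 31-fold higher number from compound 1 to compound 2 (1.50 log units; beyond the scatter), which replaces the amide substituent.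

Compound 4 `CCN(CC)CCCNC(=O)c1ccc(C(CC)(CC)c2ccc(OCC(O)C(C)(C)C)c(C)c2)n1CC` differs from compound 3 only at that amide nitrogen: 3-(diethylamino)propyl in place of 1-(methoxycarbonyl)-2-methylbutyl on an amide-type nitrogen. The step that bears on it is the exchange at the same nitrogen from compound 1 to compound 2, a large rise in the number; the exchange here is a different one, so its size is a guide, not a measure. Compound 4 is therefore expected to sit higher than compound 3, by a step of about a 9.6-fold higher number from compound 3 to compound 4 (0.98 log units; beyond the scatter) in this assay, with considerable uncertainty. The estimate for compound 4 is 250 nM, within a range from 50 nM to 1500 nM.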

Compound 4, half-maximal effective concentration: 66 nM
Beside the measured number, compound 4's estimate is 3.8-fold (0.58 log units) above it; the measured number falls inside the stated range.
By their numbers in this assay, from the lowest: compound 3; then compound 4; then compound 1; then compound 2.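

With the 1-hydroxy-2,2-dimethylpropyl group held constant, the amide-type nitrogen accepts a very different substituent at modest cost: 3-(diethylamino)propyl in place of 1-(methoxycarbonyl)-2-methylbutyl gives a 2.5-fold higher number from compound 3 to compound 4 (0.40 log units; beyond the scatter). The methyl ester and the defined stereocentres of the leaving group are therefore not needed for a low number here, and the large step seen earlier at this place, a 31-fold higher number from compound 1 to compound 2 (1.50 log units; beyond the scatter), does not apply to every exchange there, although that step was read on the (tert-butyl)carbonyl compounds and with a different incoming group. No measured evidence is available to explain the size of this step.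

As far as these compounds go, whether 3-(diethylamino)propyl behaves the same way with (tert-butyl)carbonyl in place of the 1-hydroxy-2,2-dimethylpropyl group remains open. Also open, from the compounds shown here alone, is how a carboxylic acid in place of the methyl ester, or a shorter chain to the diethylamino group, would read.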